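The compounds below may be only part of what the source reports. "The series", "measured", "known", "first", "only" and "open" are said of these compounds alone.

In a functional assay on SK-N-SH cells (Homo sapiens) for cytotoxicity, read by MTT assay, with a stated time of 48 h (a higher number here means a weaker inhibitor, a lower number a stronger inhibitor), compound 1 (`Cc1[nH]c2ccccc2c1C1(c2c(C)[nH]c3ccccc23)C(=O)Nc2ccccc21`) gives 980 nM. Compound 2 (`O=C1Nc2ccccc2C1(c1c(-c2ccccc2)[nH]c2ccccc12)c1c(-c2ccccc2)[nH]c2ccccc12`) gives 9600 nM, the higher of the two numbers, and the gap between them lies beyond the scatter. Compound 3 (`O=C1Nc2ccc(Cl)cc2C1(c1c(-c2ccccc2)[nH]c2ccccc12)c1c(-c2ccccc2)[nH]c2ccccc12`) carries chloro in place of hydrogen on an aromatic carbon of compound 2 (chloro in place of hydrogen on an aromatic carbon). Among the compounds with values here, no measured pair shows this change, so only a small move toward a lower number is expected, possibly within the scatter. The expected step is a 1.6-fold lower number from compound 2 to compound 3 (0.20 log units; within the scatter). For compound 3 the estimated value is 6000 nM, with an estimated range from 2000 nM to 15000 nM.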

Compound 3, half-maximal inhibitory concentration: > 100000 nM
Compound 3: no number, only a limit (the forecaster's own chance of this, stated with the estimate: 5%); middle value at least 16-fold (1.22 log units) from the limit.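

In this assay compound 3 gives > 100000 nM, a limit and not a number. Chloro in place of hydrogen on an aromatic carbon, meta to a fused ring and para to a fused ring, brings an at least 10-fold higher number from compound 2 to compound 3 (1.01 log units; beyond the scatter), so this position responds strongly to one chlorine. The full size of the step stays unknown, since one end of it is only a limit: the limit of > 100000 nM in this assay, at which 1 of the 3 values shown sits.

Going by these compounds, whether the rise belongs to chloro alone stays open; fluoro, methoxy or an amine at this position would test that. On these data alone, the effect of chloro on compound 1 also stays open.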